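This account rests on a few compounds, and the source may have more. Where it says the series, first, only, none or still open, it means among the compounds named here.

Compound 2 `COc1ccc(C(=O)/C=C\Nc2ccc(-c3nc4cc(OC)c(OC)c(OC)c4s3)cc2)cc1O`, compound 1 `COc1cc(OC)c2sc(-c3ccc(N/C=C\C(=O)c4ccc(OC)c(O)c4)cc3)nc2c1` and compound 3 `COc1ccc(C(=O)/C=C\Nc2ccc(-c3nc4cc(OC)c(OC)c(OC)c4s3)cc2)cc1F` share a common core, while compound 4 `COc1cc(OC)c2sc(-c3ccc(N/C=C\C(=O)c4ccc(OC)c(F)c4)cc3)nc2c1` has not yet been tested. In a functional assay on MIA PaCa-2 cells (Homo sapiens) for antiproliferative activity, read by sulforhodamine B assay, with a stated time of 48 h (a lower number here means a stronger inhibitor, a higher number a weaker inhibitor), compound 2 gives 32800 nM, compound 1 gives 11600 nM and compound 3 gives 19400 nM. The change hydrogen in place of methoxy on an aromatic carbon brought a 2.8-fold lower number from compound 2 to compound 1 (0.45 log units; beyond the scatter), whereas the change fluoro in place of hydroxy on an aromatic carbon brought a 1.7-fold lower number from compound 2 to compound 3 (0.23 log units; within the scatter). Among the measured compounds shown here, compound 4 differs from compound 3 by hydrogen in place of methoxy on an aromatic carbon, which is the same change as the one from compound 2 to compound 1, made at a place described in exactly the same words. Compound 4 is therefore expected to show a 2.6-fold lower number from compound 3 to compound 4 (0.41 log units; beyond the scatter), because compound 1 showed a 2.8-fold lower number from compound 2 to compound 1 (0.45 log units; beyond the scatter) on this same change. The estimate for compound 4 in this assay is 7500 nM, with a likely range from 3000 nM to 18000 nM.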

Compound 4, half-maximal inhibitory concentration: 4300 nM
For compound 4 the middle estimate is 1.7-fold (0.24 log units) above the measured one; low and high end bracket the measured number.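

In this assay, hydrogen in place of methoxy brought a 4.5-fold lower number from compound 3 to compound 4 (0.65 log units; beyond the scatter), so this change carried over from one core to the other with much the same size: the same change on two cores in this assay, a 2.8-fold lower number (0.45 log units; beyond the scatter) from compound 2 to compound 1 and a 4.5-fold lower number (0.65 log units; beyond the scatter) from compound 3 to compound 4, 1.6-fold (0.20 log units) apart, within the scatter of two such steps

Fluoro in place of hydroxy brought a 2.7-fold lower number from compound 1 to compound 4 (0.43 log units; beyond the scatter), and this change also held up across the two cores, even though only this step lies beyond the scatter: the same change on two cores in this assay, a 1.7-fold lower number (0.23 log units; within the scatter) from compound 2 to compound 3 and a 2.7-fold lower number (0.43 log units; beyond the scatter) from compound 1 to compound 4, 1.6-fold (0.20 log units) apart, within the scatter of two such steps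

Each change was seen on just two cores, so this does not show that either would carry over to other cores in the series, and it does not explain why the numbers fall.

On these data alone, how an amine or a chloro group would compare with the fluoro group remains open. So does whether a longer chain in place of a methoxy group would give a lower or a higher number.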